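Replacing propanoyl with methyl on a sulfur

The compounds below may be only part of what the source reports. "The series", "measured", "known", "first", "only" and "open" are said of these compounds alone.

Measured so far in an ADME assay on HEK293 cells (Homo sapiens) for inhibition, read by MTT assay, with a stated time of 96 h; a lower number here means a stronger inhibitor of growth, a higher number a weaker inhibitor of growth
- compound 1 `CC(C)C(=O)SCCCCCCNC(=O)c1cc(-c2ccncc2)n[nH]1` gives > 50000 nM as a limit
- compound 2 `CCC(=O)SCCCCCCNC(=O)c1cc(-c2ccncc2)n[nH]1` gives > 50000 nM as a limit

Compound 2 stands at > 50000 nM which is a limit and not a number. The evidence so far is the limit of > 50000 nM in this assay, at which 2 of the 2 values shown sit, and nothing finer. Compound 3 `CSCCCCCCNC(=O)c1cc(-c2ccncc2)n[nH]1` differs from compound 2 by methyl in place of propanoyl on a sulfur with methyl in place of propanoyl on a sulfur. Among the compounds with values here, the one measured step is a step that the two limits leave unreadable from compound 1 to compound 2 and it gives no size to carry over. The step expected in this assay is a number no higher from compound 2 to compound 3 (the limit leaves the size open) and nothing beyond the scatter. Compound 3 is expected near 50000 nM with an estimated range from 20000 nM to 100000 nM and may well return only a limit.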

Compound 3, concentration for 50% growth inhibition: > 50000 nM
Compound 3 gave a limit, no number (the forecaster's own chance of this, stated with the estimate: 75%); the middle value lies on the limit itself.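

Compound 1, compound 2 and compound 3 each give only a limit in this assay, so no step among them can be read: the limit of > 50000 nM in this assay, at which 3 of the 3 values shown sit.

The compounds shown leave open how strongly each inhibits growth, and whether methyl in place of propanoyl on the sulfur changes that at all.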